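The source may report more compounds than this note shows. Statements on the series, on what has been measured and on what is new or still open speak of the compounds shown alone.

In a functional assay on HCT-116 cells (Homo sapiens) for antiproliferative activity, read by MTT assay, with a stated time of 48 h (a lower number here means a stronger inhibitor, a higher number a weaker inhibitor), compound 1 `CCCCC(CCO)n1cnc2c(OC)ncnc21` gives > 50000 nM, which is a limit of the assay and not a number. Compound 2 `CCCCC(CCO)n1cnc2c(N)ncnc21` gives > 50000 nM, which is also a limit and not a number. Compound 2 therefore has no exact position on the scale, and the evidence so far is the limit of > 50000 nM in this assay, at which 2 of the 2 values shown sit.

Going by the values given here, the only measured step is a step that the two limits leave unreadable from compound 1 to compound 2, with amino in place of methoxy on an aromatic carbon. It offers no size to carry forward.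

Compound 3 `CCCCC(CCO)n1cnc2cncnc21` changes that same aromatic carbon again: hydrogen in place of amino on an aromatic carbon. This is hydrogen in place of amino on an aromatic carbon. With only a step that the two limits leave unreadable from compound 1 to compound 2 to draw on, the data give no reason to expect a gain or a loss in this assay, and another limit seems the likeliest report.

The estimated step is a step that the limit leaves unreadable from compound 2 to compound 3, and no change beyond the usual scatter is expected.

Compound 3 is expected to give about 60000 nM, with an estimated range from 30000 nM to 120000 nM.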

Compound 3, half-maximal inhibitory concentration: > 50000 nM
Compound 3: a limit, no number; the forecaster's own chance of this, stated with the estimate: 85%; the middle value does not contradict the limit.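

Compound 3 also gives a limit and not a number, so its steps from compound 1 and from compound 2 cannot be read in this assay. The position now stands as follows: the limit of > 50000 nM in this assay, at which 3 of the 3 values shown sit.

The compounds shown leave open whether methoxy, amino or hydrogen on this aromatic carbon makes any difference to the activity.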